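Adding One Methoxy Group to Compound 3

A few compounds are considered here, and "the series" means these few. Any claim that something is new, unique, unknown or untested is made for them only; others in the source may bear on it.

Compound 1 `COc1cccc(/C=C2\CCC/C(=C\c3cc(OC)c(OC)c(OC)c3)C2=O)c1OC` and compound 2 `COc1ccc(/C=C2\CCC/C(=C\c3ccc(OC)c(OC)c3)C2=O)cc1OC` and compound 3 `COc1cc(/C=C2\CCC/C(=C\c3ccc(OC)c(OC)c3)C2=O)cc(OC)c1` share a core and differ in their methoxy groups. In a functional assay on HT-1080 cells (Homo sapiens) for cytotoxicity, read by MTT assay, with a stated time of 72 h (a lower number here means a stronger inhibitor, a higher number a weaker inhibitor), compound 1 gives 2300 nM while compound 2 gives 3000 nM and compound 3 gives 2600 nM as its read-out. Compound 3 stands close to both of the others, within the usual scatter of repeated measurements, so these three numbers cannot be ranked.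

Compound 4 `COc1ccc(/C=C2\CCC/C(=C\c3cc(OC)c(OC)c(OC)c3)C2=O)cc1OC` differs from compound 3 by a single change methoxy in place of hydrogen on an aromatic carbon in which methoxy replaces hydrogen on an aromatic carbon, ortho to two methoxy groups and para to a large group. Within the data shown here, no measured pair shows this change on its own, so there is no direct precedent for its size. Among the measured compounds shown here, the only guide is that the three measured compounds, despite their different methoxy groups, remain within the scatter of one another. Three compounds are a small basis, so a surprise remains possible. In this assay no step beyond the scatter is expected, in either direction. The estimate means a 1.1-fold lower number from compound 3 to compound 4 (0.05 log units; within the scatter) as the expected step. For compound 4 the estimated value is 2300 nM with an expected range from 1100 nM to 4700 nM when it is measured.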

Compound 4, half-maximal inhibitory concentration: 1100 nM
The estimate for compound 4 lay 2.1-fold (0.32 log units) above the measured number, and the stated range covers the measured number.
By their numbers in this assay, from the lowest: compound 4; then compounds 1, 3 and 2 (each within the scatter of the next).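

Among these compounds, the gain in compound 4 is the first step to go beyond the scatter: in this assay, methoxy in place of hydrogen, ortho to two methoxy groups and para to a large group, gives a 2.4-fold lower number from compound 3 to compound 4 (0.37 log units; beyond the scatter) in this position, and the same kind of change starting from compound 2 gives a 2.7-fold lower number from compound 2 to compound 4 (0.44 log units; beyond the scatter) as well. The number of methoxy groups alone does not settle the matter, since compound 1 carries as many as compound 4, and yet 3,4-dimethoxyphenyl in place of 2,3-dimethoxyphenyl gives a 2.1-fold lower number from compound 1 to compound 4 (0.32 log units; beyond the scatter) with no other change, so the arrangement of the methoxy groups matters as well as their number. These steps are modest, and nothing shown gives a measured reason for them.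

As far as these compounds go, whether methoxy itself is needed at this carbon remains open, as a hydroxyl group, an ethoxy group or an amine there could give a different number. From the compounds shown here alone, it also remains open whether the gain would persist with a longer chain on the oxygen or with a chlorine atom in place of the methoxy.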